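This account rests on a few compounds, and the source may have more. Where it says the series, first, only, none or still open, it means among the compounds named here.

Compound 1 `CN(C)S(=O)(=O)CCNc1nonc1/C(=N/O)Nc1ccc(F)c(Br)c1` gives 105 nM in an assay on isolated protein for inhibition of Indoleamine 2,3-dioxygenase 1 (Homo sapiens), read by fluorescence, with a stated time of 60 min; a lower number here means a stronger inhibitor, a higher number a weaker inhibitor. Compound 2 `O=S(=O)(CCNc1nonc1/C(=N/O)Nc1ccc(F)c(Br)c1)N1CCC1` gives 191 nM in this assay; among the two numbers it stands highest, with compound 1 nearest, and the step of a 1.8-fold higher number from compound 1 to compound 2 (0.26 log units; within the scatter) separates them. Compound 3 `NS(=O)(=O)CCCNc1nonc1/C(=N/O)Nc1ccc(F)c(Br)c1` is not yet measured. It differs from compound 2 by sulfamoylmethyl in place of (azetidin-1-yl)sulfonyl on a saturated chain carbon, two bonds along the chain from a nitrogen on an aromatic ring. Within the data shown here, only one measured step bears on this change, the exchange of one substitution on the sulfonyl nitrogen for another from compound 1 to compound 2, which was a 1.8-fold higher number from compound 1 to compound 2 (0.26 log units; within the scatter). Nothing measured here covers the extra chain carbon or the unsubstituted sulfonamide. The expectation is therefore a step from compound 2 to compound 3 of a 1.0-fold higher number from compound 2 to compound 3 (0.02 log units; within the scatter), with no direction claimed beyond the scatter. Compound 3 is expected to give about 200 nM in this assay, in a range from 70 nM to 600 nM.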

Compound 3, half-maximal inhibitory concentration: 126 nM
Compound 3: middle estimate off by 1.6-fold (0.20 log units), on the high side; the range from low to high includes it.
By their numbers in this assay, from the lowest: compounds 1, 3 and 2 (each within the scatter of the next).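

At this position, the change from 2-((azetidin-1-yl)sulfonyl)ethyl to 3-sulfamoylpropyl removes the four-membered ring, adds a hydrogen-bond donor and gives a 1.5-fold lower number from compound 2 to compound 3 (0.18 log units; within the scatter) in this assay. Sulfamoylmethyl in place of dimethylsulfamoyl gives a 1.2-fold higher number from compound 1 to compound 3 (0.08 log units; within the scatter), so a longer chain ending in an unsubstituted sulfonamide lies within the scatter of both substituted sulfonamides, although chain length and sulfonamide substitution change together and cannot be separated here. No evidence on the reason for these results is at hand.

A 3-sulfamoylpropyl chain bearing dimethylamino on the sulfonyl sulfur would be needed to separate those two changes. Also open, on these data alone, is whether a carboxylic acid or an amine at the end of the chain would fall within the same scatter.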